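The source may hold more compounds than are shown below. What is called first, only, known or untested is meant among the compounds shown, and "the series" means these compounds.

Working notes on the series. Compound 1 `Cc1c(OCCCCOc2ccccc2C(=O)O)ccc(C(=O)CC2CCCC2)c1O` gives 98.8% in an assay on HEK293 cells for positive allosteric modulation of metabotropic glutamate receptor 2 (Rattus norvegicus), read by thallium flux, with a stated time of 2.5 min; on this read-out higher numbers stand for larger maximal responses and lower numbers for smaller maximal responses. Compound 2 `CCCC(=O)c1ccc(OCCCCOc2cc(C(=O)O)ccc2OC)c(C)c1O` gives 82.8% in this assay, and compound 3 `Cc1c(OCCCCOc2cccc(C(=O)O)c2)ccc(C(=O)CC2CCCC2)c1O` gives 80.6%. Compound 3 holds the lowest of the three numbers; its nearest neighbour is compound 2, within the scatter, and its furthest is compound 1, beyond the scatter. Among the compounds with values here, the only single-point step so far, a number 18.2 percentage points lower from compound 1 to compound 3 (beyond the scatter), went with 3-carboxyphenyl in place of 2-carboxyphenyl on an oxygen on a saturated carbon.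

Compound 4 `COc1ccc(C(=O)O)cc1OCCCCOc1ccc(C(=O)CC2CCCC2)c(O)c1C` has not yet been measured. Compared with compound 3 the change is methoxy in place of hydrogen on an aromatic carbon, which reads, cut one bond further out, as 3-carboxyphenyl to 5-carboxy-2-methoxyphenyl. Within the data shown here, no measured step covers this change; the one step measured concerns the position of the carboxy group, not a methoxy. Compound 2, which carries 5-carboxy-2-methoxyphenyl but a different acyl group, and compound 3 give values within the scatter of each other. A step of a number 1.4 percentage points higher from compound 3 to compound 4 (within the scatter) within the scatter is therefore expected. Compound 4 is estimated at 82%, between 68% and 96%.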

Compound 4, largest response reached (reported as percent of maximum), in percent of the reference or control that the assay uses: 91.8%
For compound 4 the middle estimate is 9.8 percentage points below the measured one, and the stated range covers the measured number.
By their numbers in this assay, from the lowest: compounds 3, 2, 4 and 1 (each within the scatter of the next, the first and the last beyond it).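

In this assay, methoxy in place of hydrogen on an aromatic carbon, ortho to a large group and para to a carboxy group, gives a number 11.2 percentage points higher from compound 3 to compound 4 (beyond the scatter) and so shows that this position on the carboxyphenyl ring can take a substituent with a step beyond the scatter. With the 5-carboxy-2-methoxyphenyl group held, cyclopentyl in place of ethyl gives a number 9 percentage points higher from compound 2 to compound 4 (within the scatter) and does not separate the two acyl side chains. Set against the 2-carboxyphenyl group, the 5-carboxy-2-methoxyphenyl group gives a number 7 percentage points lower from compound 1 to compound 4 (within the scatter) and leaves these two groups unresolved.

Open, as far as these compounds go, is whether ethoxy, a hydroxy group or a chlorine atom at this carbon would behave like methoxy, and whether the methoxy step would persist on the 2-carboxyphenyl group. No available data explain the methoxy step.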